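From Ethylamino to Isopropylamino on the Shared Core

This account rests on a few compounds, and the source may have more. Where it says the series, first, only, none or still open, it means among the compounds named here.

Compound 1 `O=S1(=O)N=C(NC2CCC2)Nc2c(Cl)cccc21` gives 126000 nM
Compound 2 `CCNC1=NS(=O)(=O)c2cc(Cl)ccc2N1` gives 39900 nM

In a functional assay on aorta (Rattus norvegicus) for inhibition (on this read-out lower numbers stand for an effect already at smaller amounts and higher numbers for an effect only at larger amounts of compound), compound 2 gives 39900 nM as the lower of the two numbers, and compound 1 stands at 126000 nM with a gap beyond the usual scatter. The two compounds differ in more than one place, so this gap cannot be traced to a single structural change.

Compound 3 `CC(C)NC1=NS(=O)(=O)c2cc(Cl)ccc2N1` has not yet been measured. It derives from compound 2 through one change methyl in place of hydrogen on a saturated chain carbon bound to an amine nitrogen and a saturated chain carbon that turns ethylamino into isopropylamino, with methyl in place of hydrogen on a saturated chain carbon bound to an amine nitrogen and a saturated chain carbon.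

Within the data shown here, no measured pair shows this change, so the expectation starts from compound 2 at 39900 nM and has no measured step to guide it. No step beyond the scatter is expected, although a slight lean toward a lower number is assumed. The estimate means a 1.6-fold lower number from compound 2 to compound 3 (0.20 log units; within the scatter) as the expected step. The value expected in this assay for compound 3 is 25000 nM within a range from 8000 nM to 80000 nM on this estimate.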

Compound 3, half-maximal effective concentration: 36300 nM
For compound 3 the middle estimate is 1.5-fold (0.16 log units) below the measured one, within the range that was stated.
By their numbers in this assay, from the lowest: compounds 3 and 2 (each within the scatter of the next); then compound 1.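

In this assay the step is a 1.1-fold lower number from compound 2 to compound 3 (0.04 log units; within the scatter) and so stays within the usual scatter: ethylamino and isopropylamino on the shared core cannot be told apart on this read-out. Compound 1 and compound 2 differ in more than one place, so they could say nothing about this position, whereas this pair isolates one change, methyl in place of hydrogen on a saturated chain carbon bound to an amine nitrogen and a saturated chain carbon, and shows that this single methyl does not separate the two compounds. No measurement at hand offers an explanation for this result.

From the compounds shown here alone, it remains open whether this position would accept other groups in the same way, such as a longer chain, a cyclopropyl ring, or a chain ending in a hydroxyl group or a carboxylic acid. Compound 1 carries cyclobutylamino but differs from compound 2 and compound 3 in more than one place, so what a ring at this position does on the shared core also remains unsettled.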